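Replacing Phenyl with Pyridin-3-yl: From Compound 1 to Compound 3

The source may hold more compounds than are shown below. What is called first, only, known or untested is meant among the compounds shown, and "the series" means these compounds.

Measured so far:
compound 1 `CCOC(=O)C1=C(Nc2ccccc2)S/C(=C\c2ccccc2)C1=O` — 42.9%
compound 2 `CCOC(=O)C1=C(Nc2ccc(Br)cc2)S/C(=C\c2ccc[nH]2)C1=O` — 17%

Of the compounds shown here, two built on a shared core have been tested in a functional assay on K562 cells (Homo sapiens) for inhibition, read by MTT assay, with a stated time of 72 h, tested at 10 uM; on this read-out higher numbers stand for more inhibition at the one concentration tested (going by the name of the read-out) and lower numbers for less inhibition. Compound 1 gives 42.9% and stands highest of the two numbers. Its nearest neighbour, compound 2, gives 17%, a number that lies beyond the scatter below it. Compound 2 differs from compound 1 in more than one place, so no single change can be read from the gap between them; the two values show only that the combination carried by compound 2 goes with less inhibition.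

Compound 3 `CCOC(=O)C1=C(Nc2ccccc2)S/C(=C\c2cccnc2)C1=O` has not yet been tested in this assay. It differs from compound 1 in one place: pyridin-3-yl in place of phenyl on a double-bonded chain carbon bound to a double-bonded ring carbon. For the measured compounds named here, no measured pair shows the effect of this one change, so the direction of the step in this assay is open. The account expects a small shift, toward lower inhibition, of a size near the edge of the scatter, written as a number 7.9 percentage points lower from compound 1 to compound 3 (within the scatter). On that basis compound 3 is estimated to give 35% in this assay, within a range from 15% to 55%.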

Compound 3, a percentage reported as inhibition, at one concentration (the size of the read-out at that concentration, not a potency): < 10%
Compound 3 ended at the assay's limit; the forecaster's own chance of this, stated with the estimate: 0%; middle value at least 25 percentage points from the limit.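

For the compounds shown here, with the rest of compound 1 unchanged, pyridin-3-yl in place of phenyl on a double-bonded chain carbon bound to a double-bonded ring carbon gives, in this assay, a number at least 32.9 percentage points lower from compound 1 to compound 3 (beyond the scatter), the first change in one place that can be read. The two groups have the same count of heavy atoms and differ by a ring nitrogen in place of a ring carbon, along with the hydrogen-bond acceptor counted for pyridin-3-yl, so an exchange within the ring at this position is enough to separate the two compounds beyond the scatter. The value of compound 3, < 10%, is a limit of the assay and not a number, so the step gives only a bound on the size of the loss: the limit of < 10% in this assay, at which 1 of the 3 values shown sits.

The compounds shown leave open whether the loss depends on where the ring nitrogen sits, which pyridin-2-yl or pyridin-4-yl at the same place would address. They also leave open whether a hydrogen-bond acceptor carried outside the ring, as in 4-methoxyphenyl, or an amine such as 4-dimethylaminophenyl, would go with a similar fall.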